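A few compounds are considered here, and "the series" means these few. Any claim that something is new, unique, unknown or untested is made for them only; others in the source may bear on it.

Measured so far in a functional assay (Cavia porcellus) with sulfonylurea receptors; K-ATP channels (Homo sapiens) as the target; a higher number here means a weaker inhibitor, a lower number a stronger inhibitor:
compound 1 `CC(O)(C(=O)Nc1ccc(S(=O)(=O)c2cccc(F)c2)cc1)C(F)(F)F` gives 3400 nM
compound 2 `CC(O)(C(=O)Nc1ccc(S(=O)(=O)c2ccc(C#N)cc2)cc1)C(F)(F)F` gives > 30000 nM, which is a limit of the assay and not a number
compound 3 `CC(O)(C(=O)Nc1ccc(S(=O)(=O)c2ccccc2O)cc1)C(F)(F)F` gives 3090 nM

Compound 3 and compound 1 sit close together, as a 1.1-fold lower number from compound 1 to compound 3 (0.04 log units; within the scatter) shows, while the change from the limit of compound 2 is large: an at least 9.7-fold lower number from compound 2 to compound 3 (0.98 log units; beyond the scatter). Compound 4 `COc1ccccc1S(=O)(=O)c1ccc(NC(=O)C(C)(O)C(F)(F)F)cc1` differs from compound 3 by methyl in place of hydrogen on an oxygen on an aromatic ring. Within the data shown here, none of the measured steps touches that oxygen; all of them exchange the whole ring on the sulfonyl sulfur, one of them small (a 1.1-fold lower number from compound 1 to compound 3 (0.04 log units; within the scatter)) and two of them large (an at least 8.8-fold higher number from compound 1 to compound 2 (0.94 log units; beyond the scatter), an at least 9.7-fold lower number from compound 2 to compound 3 (0.98 log units; beyond the scatter)). So no step beyond the scatter is expected in this assay, and the estimate for compound 4 is 3500 nM, between 1200 nM and 10000 nM, a step of a 1.1-fold higher number from compound 3 to compound 4 (0.05 log units; within the scatter).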

Compound 4, half-maximal inhibitory concentration: 1600 nM
The estimate for compound 4 lay 2.2-fold (0.34 log units) above the measured number; the measured number falls inside the stated range.
By their numbers in this assay, from the lowest: compounds 4, 3 and 1 (each within the scatter of the next, the first and the last beyond it). At a limit, above all of these: compound 2.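

In this assay, putting methyl on the oxygen, hydroxy to methoxy, leaves inhibition within the scatter: a 1.9-fold lower number from compound 3 to compound 4 (0.29 log units; within the scatter), so the hydrogen on that oxygen is not required at this level of inhibition. Yet only the 2-methoxyphenyl ring, not the 2-hydroxyphenyl ring, separates from the 3-fluorophenyl ring: a 2.1-fold lower number from compound 1 to compound 4 (0.33 log units; beyond the scatter). Compound 2 stands at a limit and not a number, so an at least 18-fold lower number from compound 2 to compound 4 (1.27 log units; beyond the scatter) is only a bound: the limit of > 30000 nM in this assay, at which 1 of the 4 values shown sits.

Still open, from the compounds shown here alone, is whether an ethyl group or a longer chain on that oxygen keeps this level of inhibition, and whether an amine in place of the hydroxy group does.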